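The source may report more compounds than this note shows. Statements on the series, on what has been measured and on what is new or still open speak of the compounds shown alone.

Compound 2, `Cc1oc(-c2ccc(F)cc2)nc1CN1CCC(C(=O)NCCCN2C[C@H](C)C[C@H](C)C2)CC1`, gives 0.468 h in an ADME assay on microsomes from liver (Rattus norvegicus) for metabolic stability, read by LC-MS, using NADPH, at 37 degrees C; a lower number here means that the compound disappears faster, a higher number that the compound lasts longer. This is the highest of the three numbers shown: compound 1, `Cc1ccccc1-c1nc(CN2CCC(C(=O)NCCCN3CCC(C(C)C)CC3)CC2)c(C)o1`, gives 0.147 h, a value beyond the scatter below it, and compound 3, `Cc1cccc(Cl)c1-c1nc(CN2CCC(C(=O)NCCCN3CCCC(C)C3)CC2)c(C)o1`, gives 0.09 h, further below still. Going by the values given here, neither of these two compounds shares the tail of compound 2, so no single-change step toward compound 2 can be drawn from them.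

Compound 4, `Cc1ccc(-c2nc(CN3CCC(C(=O)NCCCN4C[C@H](C)C[C@H](C)C4)CC3)c(C)o2)c(C)c1`, differs from compound 2 in one place: 2,4-dimethylphenyl in place of 4-fluorophenyl on an aromatic carbon. Its tail is kept, so the comparison rests on the aromatic group alone.

Among the compounds with values here, no measured pair isolates this kind of change. Compound 1, which carries a methyl-bearing phenyl group, gives 0.147 h in this assay, but it also carries a different tail, so its number is only a loose pointer. A decrease of moderate size is expected for compound 4, with a 2.3-fold lower number from compound 2 to compound 4 (0.37 log units; beyond the scatter) as the estimated step, likely beyond the scatter. Compound 4 is thus estimated at 0.2 h, within a range from 0.08 h to 0.5 h.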

Compound 4, half-life: > 0.5 h
Compound 4: a limit, no number; the forecaster's own chance of this, stated with the estimate: 5%; at least 2.5-fold (0.39 log units) between middle value and limit.
By their numbers in this assay, from the lowest: compounds 3 and 1 (each within the scatter of the next); then compound 2. At a limit, above all of these: compound 4.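

Compound 4 stands at a limit of this assay, not at a number: the limit of > 0.5 h in this assay, at which 1 of the 4 values shown sits. Going by these compounds alone, this gives the first single-change step at this position, an at least 1.0-fold higher number from compound 2 to compound 4 (0.02 log units; that floor lies within the scatter), and since that floor lies within the scatter, the size of the step cannot be read. Within the data shown here, what it does show is that, with the tail of compound 2 kept, 2,4-dimethylphenyl in place of 4-fluorophenyl on this aromatic carbon brings no measured fall in half-life, a drop the earlier compounds could neither support nor exclude.

Going by these compounds, how far the half-life of compound 4 lies past its limit remains open, and so does whether the outcome follows from the methyl groups or from the loss of fluorine. On these data alone, how an unsubstituted phenyl group, a pyridyl group or a methoxyphenyl group would fare on this carbon also remains open.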